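A few compounds are considered here, and "the series" means these few. Any claim that something is new, unique, unknown or untested is made for them only; others in the source may bear on it.

Working notes on the series. The shared core carries a piperazine-linked acetamide whose anilide aryl is varied; compound 1 `O=C(CN1CCN(c2nnc(Cc3ccncc3)c3ccccc23)CC1)Nc1ccc(Br)cc1` bears the 4-bromophenyl anilide and a pyridin-4-yl methyl group on the core. In a functional assay on A549 cells (Homo sapiens) for cytotoxicity, read by MTT assay, with a stated time of 72 h (a lower number here means a stronger inhibitor, a higher number a weaker inhibitor), compound 1 gives 2710 nM. Compound 3 `O=C(CN1CCN(c2nnc(Cc3ccccc3)c3ccccc23)CC1)Nc1ccc(Br)cc1` gives 2000 nM, and the two numbers lie within the scatter of each other: a 1.4-fold lower number from compound 1 to compound 3 (0.13 log units; within the scatter), phenyl in place of pyridin-4-yl on a saturated chain carbon bound to an aromatic carbon. Compound 2 `COc1ccc(NC(=O)CN2CCN(c3nnc(Cc4ccccc4)c4ccccc34)CC2)cc1OC`, with a 3,4-dimethoxyphenyl anilide, is reported in this assay as "not active" (no number reported), with no number given.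

Compound 4 `Cc1ccc(F)cc1NC(=O)CN1CCN(c2nnc(Cc3ccncc3)c3ccccc23)CC1` is not yet measured. Relative to compound 1 the change is 5-fluoro-2-methylphenyl in place of 4-bromophenyl on an amide-type nitrogen. For the measured compounds named here, no measured step covers this position directly; the only related observation is that compound 2, with a different anilide aryl, gave "not active" (no number reported), whereas compound 3 with the 4-bromophenyl anilide gave 2000 nM. For compound 4 a step towards a weaker number in this assay is therefore expected and is estimated as a 2.0-fold higher number from compound 1 to compound 4 (0.31 log units; beyond the scatter), with wide uncertainty. Compound 4 is estimated at 5500 nM, within a range of 1800 nM to 20000 nM.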

Compound 4, half-maximal inhibitory concentration: 38900 nM
Estimate against measurement, compound 4: 7.1-fold (0.85 log units) below; measured number above the stated range.
By their numbers in this assay, from the lowest: compounds 3 and 1 (each within the scatter of the next); then compound 4.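

In this assay, for the compounds shown here, 5-fluoro-2-methylphenyl in place of 4-bromophenyl on the amide-type nitrogen gives a 14-fold higher number from compound 1 to compound 4 (1.16 log units; beyond the scatter), the first step with numbers at both ends at this position. The anilide aryl therefore moves the number beyond the scatter, whereas the change on the other side of the shared core, a 1.4-fold lower number from compound 1 to compound 3 (0.13 log units; within the scatter), does not. No measured evidence on the origin of this step is available.

The compounds shown do not separate the loss of the 4-bromophenyl group from the arrival of the 5-fluoro-2-methylphenyl group, since no anilide aryl carrying only the fluorine or only the methyl group is among them. On these data alone, it also remains open how an unsubstituted phenyl or an aryl bearing a carboxylic acid would read at this position, and whether the step holds with phenyl in place of pyridin-4-yl.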